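Carboxy replaces methylsulfanyl on the side chain of the core

This account rests on a few compounds, and the source may have more. Where it says the series, first, only, none or still open, it means among the compounds named here.

Measured compounds:
compound 1 `Cc1nc2c(OCc3ccccc3)cccn2c1CCC#N`, 20%
compound 2 `CCOCc1c(C)nc2c(OCc3ccccc3)cccn12`, 35%
compound 3 `CSCc1c(C)nc2c(OCc3ccccc3)cccn12`, 8%

In a functional assay on the whole organism (stomach) for inhibition, with Canis familiaris (Canis lupus familiaris) as the target, at a dose of 5 mg/kg by the intravenous route (a lower number here means a weaker effect, a higher number a stronger effect of the compound at the dose given), compound 3 stands lowest of the three. Compound 4 `Cc1nc2c(OCc3ccccc3)cccn2c1CC(=O)O` has not been measured; it differs from compound 3 by carboxy in place of methylsulfanyl on a saturated chain carbon bound to an aromatic carbon. Going by the values given here, two measured steps bear on this change, since each ends at the methylsulfanyl group: a number 12 percentage points lower from compound 1 to compound 3 (beyond the scatter) and a number 27 percentage points lower from compound 2 to compound 3 (beyond the scatter). Both show that exchanging the group on that chain carbon moves this assay modestly, and both other groups gave higher numbers than methylsulfanyl. Among the compounds with values here, no measured step shows a carboxy group, so the direction rests only on methylsulfanyl being the weakest case seen. A modest rise is therefore expected, a number 17 percentage points higher from compound 3 to compound 4 (beyond the scatter). Compound 4 is estimated at 25%, within 5% to 50%.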

Compound 4, a percentage reported as inhibition, in the whole organism at one dose (the size of the read-out at that dose, not a potency): 24%
Beside the measured number, compound 4's estimate is 1 percentage points above it, and the stated range covers the measured number.
By their numbers in this assay, from the lowest: compound 3; then compounds 1 and 4 (each within the scatter of the next); then compound 2.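

In this assay a carboxy group on this chain carbon gives a higher number than methylsulfanyl (a number 16 percentage points higher from compound 3 to compound 4 (beyond the scatter)) but does not reach the number of the ethoxy compound (a number 11 percentage points lower from compound 2 to compound 4 (beyond the scatter)). Carboxy cannot be told apart from cyanomethyl (a number 4 percentage points higher from compound 1 to compound 4 (within the scatter)), so ethoxy remains the highest of the four groups and methylsulfanyl the lowest. As far as these compounds go, how an amine or an amide would fare at this place stays open. Nothing available here gives a reason for these differences.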